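Swapping 4-methoxyphenyl for 3-hydroxyphenyl on compound 2

The compounds below may be only part of what the source reports. "The series", "measured", "known", "first", "only" and "open" are said of these compounds alone.

Compound 1 `CCCOC(=O)N1N=C(c2ccc(OC)cc2)CC1c1cc(OC)c(OC)c(OC)c1` and compound 2 `COc1ccc(C2=NN(C(=O)OCc3ccccc3)C(c3cc(OC)c(OC)c(OC)c3)C2)cc1` share one core and differ only in the chain on the oxygen next to the carbonyl group. In a functional assay on HeLa cells (Homo sapiens) for antiproliferative activity, read by MTT assay, with a stated time of 48 h (on this read-out higher numbers stand for weaker inhibition of growth and lower numbers for stronger inhibition of growth), compound 1 gives > 10000 nM, which is a limit of the assay and not a number. In this assay compound 2 gives > 10000 nM, which is likewise a limit. Together they stand at the limit of > 10000 nM in this assay, at which 2 of the 2 values shown sit. Going by the values given here, the only measured step is a step that the two limits leave unreadable from compound 1 to compound 2, so it offers no size to carry forward, and it concerns a different place in the structure.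

Compound 3 `COc1cc(C2CC(c3cccc(O)c3)=NN2C(=O)OCc2ccccc2)cc(OC)c1OC` keeps the benzyloxycarbonyl group of compound 2 and changes elsewhere: 3-hydroxyphenyl in place of 4-methoxyphenyl on a carbon with a double bond to nitrogen. Among the compounds with values here, no measured pair shows what a change at this place does. The expectation therefore rests on compound 2 at > 10000 nM, itself a limit. The estimated change in this assay is a step that the limit leaves unreadable from compound 2 to compound 3, and no step beyond the usual scatter is expected. Compound 3 is expected at 12000 nM, with an estimated range of 2500 nM to 40000 nM.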

Compound 3, concentration for 50% growth inhibition: > 10000 nM
Compound 3: only a limit was reported (the forecaster's own chance of this, stated with the estimate: 65%); the middle value lies beyond the limit too.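

In this assay compound 3 gives > 10000 nM, which is a limit of the assay and not a number, and no step can be read from compound 2 to compound 3. The compounds shown leave open how far either change, in the chain on the oxygen or at the carbon with a double bond to nitrogen, alters growth inhibition.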